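The compounds below may be only part of what the source reports. "The series", "measured", "known", "first", "only" and "open" are said of these compounds alone.

The data on this series are thin. In a functional assay on HCT-116 cells (Homo sapiens) for antiproliferative activity, read by CCK-8 assay, with a stated time of 72 h (a lower number here means a stronger inhibitor, a higher number a weaker inhibitor), compound 1 (`CCc1ccc(SCc2ccc(/C=C/C(=O)Nc3ccccc3N)cc2)cc1`) is recorded as "not determined" (no result reported), so it offers nothing to compare. In this assay compound 2 (`COc1ccc(SCc2ccc(C(=O)Nc3ccccc3N)cc2)cc1`) gives 1640 nM. Among the compounds with values here, that is the only number available, so compound 2 cannot yet be ranked against any other compound.

Compound 3 (`CCc1ccc(SCc2ccc(C(=O)Nc3ccccc3N)cc2)cc1`) keeps the shared core of compound 2 and alters a single group, going from 4-methoxyphenyl to 4-ethylphenyl: ethyl in place of methoxy on an aromatic carbon.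

Within the data shown here, no pair of measured compounds shows what a replacement of this kind does, so the data do not fix its size or direction. The expectation therefore rests on the modest structural change alone, and no shift beyond the scatter is expected in this assay. The expected step, a 1.1-fold lower number from compound 2 to compound 3 (0.04 log units; within the scatter), is small, and its direction is uncertain. For compound 3 the estimated value is 1500 nM, with an expected range of 600 nM to 3800 nM.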

Compound 3, half-maximal inhibitory concentration: 1740 nM
Compound 3: middle estimate off by 1.2-fold (0.06 log units), on the low side; the range from low to high includes it.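

In this assay, ethyl in place of methoxy on an aromatic carbon gives a 1.1-fold higher number from compound 2 to compound 3 (0.03 log units; within the scatter) and so leaves the reading unchanged within the usual scatter. Within the data shown here, this is the first measured replacement, and it shows that, at this place para to a large group, the methoxy oxygen can give way to a carbon with no change beyond the scatter, while the number of heavy atoms stays the same. No evidence shown bears on why the two compounds read alike.

Among these compounds, the result covers only two groups of the same size at this position, so it remains open whether an amine, a carboxylic acid or a longer chain such as butyl on the same aromatic carbon would also leave the reading in place. Compound 1 shares the 4-ethylphenyl group of compound 3 but has no number to set against it, so the effect of the difference elsewhere in its structure cannot be read.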